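Adding Ethyl to the Chain of Compound 3

This account rests on a few compounds, and the source may have more. Where it says the series, first, only, none or still open, it means among the compounds named here.

Within the data shown here, in a physicochemical assay for solubility, in phosphate buffer, measured as kinetic solubility, at pH 7.4, tested at 250 uM (a higher number here means a more soluble compound, a lower number a less soluble compound), compound 3 (`CCCCCCNc1ccc(C(=O)O)cc1S(=O)(=O)N(C)C`) gives 243000 nM, the higher of the two exact numbers so far. Compound 1 (`CCCCCCCCNc1ccc(C(=O)O)cc1S(N)(=O)=O`) gives only a limit, > 250000 nM. Compound 4 (`CCCCCCCCNc1ccc(C(=O)O)cc1S(=O)(=O)N(C)C`) differs from compound 3 by ethyl in place of hydrogen on a saturated chain carbon, six bonds along the chain from a nitrogen on an aromatic ring. Among the measured compounds shown here, no measured step changes that chain. For the measured compounds named here, the one measured step, an at least 4.7-fold lower number from compound 1 to compound 2 (0.67 log units; beyond the scatter), puts methyl in place of hydrogen on a sulfonamide nitrogen, so it offers only indirect guidance. The longer chain of compound 4 is already carried by compound 2 (`CCCCCCCCNc1ccc(C(=O)O)cc1S(=O)(=O)NC`), which gives 53000 nM, so a drop beyond the scatter is expected. The estimated change is a 4.9-fold lower number from compound 3 to compound 4 (0.69 log units; beyond the scatter). Compound 4 is expected at about 50000 nM, within an estimated range of 15000 nM to 170000 nM.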

Compound 4, solubility: 52000 nM
For compound 4 the middle estimate is 1.0-fold (0.02 log units) below the measured one; the range from low to high includes it.
By their numbers in this assay, from the lowest: compounds 4 and 2 (each within the scatter of the next); then compound 3. At a limit, above all of these: compound 1.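

In this assay the chain itself now has a measured step of its own, with ethyl in place of hydrogen (a 4.7-fold lower number from compound 3 to compound 4 (0.67 log units; beyond the scatter)). A second methyl in place of hydrogen on the sulfonamide nitrogen gives a step within the scatter (a 1.0-fold lower number from compound 2 to compound 4 (0.01 log units; within the scatter)). Compound 1 is a limit, so its step to the dimethylamino compound is open at one end (an at least 4.8-fold lower number from compound 1 to compound 4 (0.68 log units; beyond the scatter)): the limit of > 250000 nM in this assay, at which 1 of the 4 values shown sits.

With only one chain step shown, a longer chain could lower the number further or not. On these data alone, a chain carrying an amine also remains open.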